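Changing the chain end of compound 3

This account rests on a few compounds, and the source may have more. Where it says the series, first, only, none or still open, it means among the compounds named here.

Compound 1 `NC(=O)c1sc2nccc(N3CCC[C@H](COCCO)C3)c2c1N` gives 320 ng.h/mL
Compound 2 `CCOCCOC[C@H]1CCCN(c2cc(C)nc3sc(C(N)=O)c(N)c23)C1` gives 1350 ng.h/mL
Compound 3 `CCOCCOC[C@H]1CCCN(c2ccnc3sc(C(N)=O)c(N)c23)C1` gives 2000 ng.h/mL

In an ADME assay on the whole organism (Rattus norvegicus, strain Fischer 344) for pharmacokinetics, with a stated time of 8 h, at a dose of 3 mg/kg by the oral route (a higher number here means more compound in the circulation at the dose given, a lower number less compound in the circulation), compound 3 (2000 ng.h/mL) stands within the scatter of compound 2 (a 1.5-fold higher number from compound 2 to compound 3 (0.17 log units; within the scatter)) and clearly apart from compound 1 (a 6.3-fold higher number from compound 1 to compound 3 (0.80 log units; beyond the scatter)). Compound 4 (`Cn1ccnc1COC[C@H]1CCCN(c2ccnc3sc(C(N)=O)c(N)c23)C1`) keeps the shared core but carries a different chain (1-methyl-1H-imidazol-2-yl in place of ethoxymethyl on a saturated chain carbon bound to an oxygen on a saturated carbon), with (1-methyl-1H-imidazol-2-yl)methyl replacing 2-ethoxyethyl. Within the data shown here, only one measured step touches this chain, ethyl in place of hydrogen on an oxygen (a 6.3-fold higher number from compound 1 to compound 3 (0.80 log units; beyond the scatter)). The other step, hydrogen in place of methyl on an aromatic carbon (a 1.5-fold higher number from compound 2 to compound 3 (0.17 log units; within the scatter)), does not touch it. Among the measured compounds shown here, no measured compound carries a ring on this chain, so the guidance is weak. A modest fall is expected (a 2.2-fold lower number from compound 3 to compound 4 (0.35 log units; beyond the scatter)). For compound 4 the estimated value is 900 ng.h/mL (range 250 ng.h/mL to 2800 ng.h/mL).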

Compound 4, area under the concentration-time curve: 45 ng.h/mL
The estimate for compound 4 lay 20-fold (1.30 log units) above the measured number; the whole stated range lies above it.
By their numbers in this assay, from the lowest: compound 4; then compound 1; then compounds 2 and 3 (each within the scatter of the next).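

In this assay, among these compounds, this chain end proves far more sensitive than the earlier compounds showed: 1-methyl-1H-imidazol-2-yl in place of ethoxymethyl gives a 44-fold lower number from compound 3 to compound 4 (1.65 log units; beyond the scatter) and, in place of hydroxymethyl, a 7.1-fold lower number from compound 1 to compound 4 (0.85 log units; beyond the scatter) at this same place. The ring-bearing chain thus falls below both the capped and the uncapped ether chains. Nothing given here accounts for this fall. As far as these compounds go, whether it belongs to this imidazole ring in particular or to any ring on the chain stays open, as does how a phenyl ring or an amine there would read.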